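Chloro in Place of Methyl, from Compound 2 to Compound 3

The source may report more compounds than this note shows. Statements on the series, on what has been measured and on what is new or still open speak of the compounds shown alone.

Going by the values given here, compound 2 `COc1cc(C(=O)c2sc(Nc3ccc(C)cc3)nc2N)cc(OC)c1OC` holds the only numbered value in a functional assay on L1210 cells (Mus musculus) for antiproliferative activity, read by cell counting, with a stated time of 2 days; on this read-out lower numbers stand for stronger inhibition and higher numbers for weaker inhibition: in this assay compound 2 gives 31 nM. Compound 1 `COc1ccc(C(=O)c2sc(Nc3ccccc3)nc2N)cc1OC` reaches only a limit of the assay, with a value of > 10000 nM. That limit is the limit of > 10000 nM in this assay, at which 1 of the 2 values shown sits, so the two values shown cannot be set against each other as a measured step.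

Compound 3 `COc1cc(C(=O)c2sc(Nc3ccc(Cl)cc3)nc2N)cc(OC)c1OC` differs from compound 2 by chloro in place of methyl on an aromatic carbon, a chloro entering where a methyl leaves, on an aromatic carbon of the six-membered ring bearing the (4-chlorophenyl)amino group. Among the compounds with values here, no pair of measured compounds that differ in one place is available to guide the size of this step. He therefore expects the step of a 1.0-fold lower number from compound 2 to compound 3 (0.01 log units; within the scatter) to stay within the usual scatter, in no firm direction. His estimate for compound 3 in this assay is 30 nM, expected to fall between 10 nM and 100 nM.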

Compound 3, half-maximal inhibitory concentration: 420 nM
Beside the measured number, compound 3's estimate is 14-fold (1.15 log units) below it; the measured number lies above the stated range.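

Going by these compounds alone, the change from 4-methylphenyl to 4-chlorophenyl is the first step in this assay that can be read, and it gives a 14-fold higher number from compound 2 to compound 3 (1.13 log units; beyond the scatter) on swapping one heavy atom for another at this position. This aromatic carbon, para to a large group, therefore does not tolerate every small group alike, and within this pair methyl gives the stronger inhibition and chloro the weaker. Nothing shown here accounts for the size of this step.

Compound 1 gives > 10000 nM in this assay, which is a limit of the assay and not a number, and steps to it cannot be read. The compounds shown leave open how an ethyl, a methoxy or an amine at this position would compare with methyl and chloro.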